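A few compounds are considered here, and "the series" means these few. Any claim that something is new, unique, unknown or untested is made for them only; others in the source may bear on it.

Three compounds share one core and differ only at the edges. Compound 1 `CN(Cc1ccc(OCCCN)cc1)c1nc2ccc(Oc3ccccc3)cc2s1` gives 49000 nM in an assay on SH-SY5Y cells for inhibition of Voltage-dependent N-type calcium channel subunit alpha-1B (Homo sapiens), read by FLIPR and calcium flux, with stated times of 600 s and 300 s, in the presence of a further agent that is not named here; a lower number here means a stronger inhibitor, a higher number a weaker inhibitor. Compound 2 `NCCCOc1ccc(CNc2nc3ccc(Oc4ccc(C(F)(F)F)cc4)cc3s2)cc1` gives 59000 nM. Compound 3 `NCCCOc1ccc(CNc2nc3ccc(Oc4ccccc4)cc3s2)cc1` gives 218000 nM, the highest number of the three, with compound 2 nearest and compound 1 furthest; the step of a 4.4-fold higher number from compound 1 to compound 3 (0.65 log units; beyond the scatter) comes with a hydrogen in place of a methyl on a nitrogen on an aromatic ring, and the step of a 3.7-fold higher number from compound 2 to compound 3 (0.57 log units; beyond the scatter) with a hydrogen in place of a trifluoromethyl on an aromatic carbon.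

Compound 4 `NC(N)=NCCCOc1ccc(CNc2nc3ccc(Oc4ccccc4)cc3s2)cc1` is not yet measured. It differs from compound 3 by a group of 4 heavy atoms (1 carbon, 3 nitrogen; no ring) in place of one nitrogen atom, on a saturated chain carbon, three bonds along the chain from an oxygen on an aromatic ring. Neither measured step touches this chain end, so neither bears directly on it; both show that single small changes elsewhere moved the number by modest amounts. Without a guide at this position, a modest step in either direction, or none beyond the scatter, is what is expected, as a 1.5-fold lower number from compound 3 to compound 4 (0.16 log units; within the scatter) expresses. For compound 4 the estimate is 150000 nM, with a range from 40000 nM to 500000 nM.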

Compound 4, half-maximal inhibitory concentration: 103000 nM
Compound 4: the middle estimate sits 1.5-fold (0.16 log units) above what was measured, and the stated range covers the measured number.
By their numbers in this assay, from the lowest: compounds 1, 2 and 4 (each within the scatter of the next, the first and the last beyond it); then compound 3.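

Among these compounds, at the chain end, which neither earlier step touched, the amino group gives way to the group of 4 heavy atoms (1 carbon, 3 nitrogen; no ring), and in this assay this brings a 2.1-fold lower number from compound 3 to compound 4 (0.33 log units; beyond the scatter) as the first reading at this position. The number therefore responds to a change here, and the amino group can be replaced without a higher number, although this step is modest, as are the two steps seen earlier. No measurement shown here explains why the number moves.

As far as these compounds go, whether a hydroxyl group, a carboxylic acid or a longer chain at this position would lower the number further remains open. So does whether the same replacement would move the number in a similar way on the methyl-bearing nitrogen of compound 1 or with the trifluoromethyl group of compound 2.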